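Extending the methylsulfanyl of compound 3 to benzylsulfanyl

This account rests on a few compounds, and the source may have more. Where it says the series, first, only, none or still open, it means among the compounds named here.

Of the compounds shown here, three sharing one core have been measured in a functional assay on MCF7 cells (Homo sapiens) for antiproliferative activity, read by MTT assay, with a stated time of 48 h; a lower number here means a stronger inhibitor, a higher number a weaker inhibitor. Compound 1 `Cc1ccc(-c2nc(NN)c3cc(Cl)ccc3n2)cc1` gives 3.76 ug/mL, compound 2 `Cc1ccc(-c2nc(NC(=O)c3ccccc3)c3cc(Cl)ccc3n2)cc1` gives 16.1 ug/mL, and compound 3 `CSc1nc(-c2ccc(C)cc2)nc2ccc(Cl)cc12` gives 8.64 ug/mL. Compound 3 therefore stands second highest of the three numbers: the two steps leading to it read a 1.9-fold lower number from compound 2 to compound 3 (0.27 log units; within the scatter) and a 2.3-fold higher number from compound 1 to compound 3 (0.36 log units; beyond the scatter).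

Compound 4 `Cc1ccc(-c2nc(SCc3ccccc3)c3cc(Cl)ccc3n2)cc1` differs from compound 3 by phenyl in place of hydrogen on a saturated chain carbon bound to a sulfur. Within the data shown here, no measured step adds a phenyl at exactly this position, so the only step that bears on it is the one from compound 1 to compound 2, where an aromatic group was likewise introduced at the substituent carried on the same core carbon and gave a 4.3-fold higher number from compound 1 to compound 2 (0.63 log units; beyond the scatter). On that single precedent, a modest rise in this assay, in the direction of a weaker inhibitor, is expected for compound 4, with a 1.5-fold higher number from compound 3 to compound 4 (0.18 log units; within the scatter) as the estimated step. The estimated value for compound 4 in this assay is 13 ug/mL, with a range from 5 ug/mL to 35 ug/mL.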

Compound 4, half-maximal inhibitory concentration: 9.66 ug/mL
Beside the measured number, compound 4's estimate is 1.3-fold (0.13 log units) above it; measured number inside the range.
By their numbers in this assay, from the lowest: compound 1; then compounds 3, 4 and 2 (each within the scatter of the next).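

In this assay, phenyl in place of hydrogen on a saturated chain carbon bound to a sulfur produces no readable change: a 1.1-fold higher number from compound 3 to compound 4 (0.05 log units; within the scatter), so this position accommodates the benzylsulfanyl group without a shift beyond the scatter. Compound 4 is also not separated from the benzamido group of compound 2 (a 1.7-fold lower number from compound 2 to compound 4 (0.22 log units; within the scatter)), whereas the aminoamino group keeps its distance (a 2.6-fold higher number from compound 1 to compound 4 (0.41 log units; beyond the scatter)), leaving compound 1 the only one of the four with the lowest number clear of compound 4. No available measurement offers an explanation for these results.

Still open, as far as these compounds go, is whether a longer chain between the sulfur and the phenyl would leave the number as flat as this step did. Also open, from the compounds shown here alone, is whether an amine or a carboxylic acid at the end of the sulfur chain would approach compound 1 at 3.76 ug/mL.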